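The source may hold more compounds than are shown below. What is called first, only, known or untested is meant among the compounds shown, and "the series" means these compounds.

Compound 1 `CON(C)C(=O)c1ccc([C@H](C)NC(=O)c2c(Cc3ccc(F)cc3)sc3c2CCOC3)cc1` gives 187 nM in a functional assay on CHO/Galpha16 cells for antagonist activity at prostaglandin E2 receptor EP4 subtype (Homo sapiens), read by calcium flux, with a stated time of 15 min; a lower number here means a stronger inhibitor, a higher number a weaker inhibitor.
Compound 2 `C[C@H](NC(=O)c1c(/N=C/c2cccc(C(F)(F)F)c2)sc2c1CCOC2)c1ccc(C(=O)O)cc1` gives > 1000 nM in this assay, a limit rather than a number.
Compound 3 `CC(C)c1ccc(Cc2sc3c(c2C(=O)N[C@@H](C)c2ccc(C(=O)O)cc2)CCOC3)cc1` gives 2.7 nM in this assay.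

Of the two numbers shown, compound 3 stands lowest, and compound 1 is its nearest neighbour, with a gap well beyond the scatter. Compound 4 `C[C@H](NC(=O)c1c(C#Cc2ccc(F)cc2)sc2c1CCOC2)c1ccc(C(=O)O)cc1` differs from compound 3 in a single place: 2-(4-fluorophenyl)ethynyl in place of 4-isopropylbenzyl on an aromatic carbon. For the measured compounds named here, no pair of measured compounds differs in this way. Any expectation therefore rests on the structural change alone. A step of moderate size towards weaker inhibition is expected from compound 3 to compound 4, roughly an 11-fold higher number from compound 3 to compound 4 (1.05 log units; beyond the scatter). Compound 4 is therefore estimated at 30 nM, within a range from 5 nM to 200 nM.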

Compound 4, half-maximal inhibitory concentration: 15.8 nM
Compound 4: middle estimate off by 1.9-fold (0.28 log units), on the high side; low and high end bracket the measured number.
By their numbers in this assay, from the lowest: compound 3; then compound 4; then compound 1. At a limit, above all of these: compound 2.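

In this assay, putting 2-(4-fluorophenyl)ethynyl in place of 4-isopropylbenzyl on the aromatic carbon next to the ring sulfur gives a 5.9-fold higher number from compound 3 to compound 4 (0.77 log units; beyond the scatter), a modest step. This position thus accepts a triple bond outside aromatic rings, and compound 4 still reads 15.8 nM. Nothing measured here accounts for the step.

The compounds shown leave open whether the triple bond or the exchange of isopropyl for fluorine carries this step. They also leave open how a nitrile or a methoxy group on that phenyl ring would read.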